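The compounds below may be only part of what the source reports. "The series", "measured", "known", "first", "only" and "open" are said of these compounds alone.

Compound 3 `CCOc1ccc(-n2nncc2CN2C(=O)C3(C(C#N)=C(N)Oc4c3c3nc5ccccc5nc3c3ccccc43)c3ccccc32)cc1` is tested in an ADME assay on L02 cells (Homo sapiens) for antiproliferative activity, read by MTT assay, with a stated time of 48 h; on this read-out lower numbers stand for stronger inhibition and higher numbers for weaker inhibition. In this assay compound 3 gives only a limit, > 50000 nM. Compound 1 `N#CC1=C(N)Oc2c(c3nc4ccccc4nc3c3ccccc23)C12C(=O)N(Cc1cnnn1-c1ccc(Br)cc1)c1ccccc12` likewise gives only a limit in this assay, > 50000 nM. Compound 2 `N#CC1=C(N)Oc2c(c3nc4ccccc4nc3c3ccccc23)C12C(=O)N(Cc1cnnn1-c1cccc(Br)c1)c1ccccc12` also gives only a limit in this assay, > 50000 nM. All three values sit at the same limit (the limit of > 50000 nM in this assay, at which 3 of the 3 values shown sit), so compound 3 stands level with the other two as far as the numbers can tell, and none of the three can be called more or less active than another.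

Compound 4 `Cc1ccc(C)c(-n2nncc2CN2C(=O)C3(C(C#N)=C(N)Oc4c3c3nc5ccccc5nc3c3ccccc43)c3ccccc32)c1` differs from compound 3 by 2,5-dimethylphenyl in place of 4-ethoxyphenyl on an aromatic nitrogen. The measured steps touching the group on this nitrogen are a step that the two limits leave unreadable from compound 1 to compound 2, a step that the two limits leave unreadable from compound 1 to compound 3 and a step that the two limits leave unreadable from compound 2 to compound 3; none of them yields a readable size because both ends of each sit at the limit (the limit of > 50000 nM in this assay, at which 3 of the 3 values shown sit). For the measured compounds named here, the exchange of a 4-ethoxyphenyl for a 2,5-dimethylphenyl thus has no measured counterpart of known size, and the expected step that the limit leaves unreadable from compound 3 to compound 4 in this assay is most likely one that again stays beyond the limit. For compound 4 in this assay the estimate is 80000 nM, within 30000 nM to 250000 nM, with a high chance that only a limit is reported.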

Compound 4, half-maximal inhibitory concentration: > 50000 nM
Compound 4 gave a limit, no number (the forecaster's own chance of this, stated with the estimate: 85%); the middle value is on the limit's open side.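

No step to compound 4 from compound 1, compound 2 or compound 3 can be read, as both ends of each step are limits: the limit of > 50000 nM in this assay, at which 4 of the 4 values shown sit.

From the compounds shown here alone, whether any group on this aromatic nitrogen changes the read-out at all, and how far each compound lies past the limit, stays open.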